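A few compounds are considered here, and "the series" means these few. Any claim that something is new, unique, unknown or untested is made for them only; others in the source may bear on it.

Compound 1 `CCn1c(SC/C(=N/O)c2ccccc2)nnc1-c1cc(OC)c(OC)c(OC)c1` was tested in a functional assay on the whole organism (strain albino) for inhibition, with Rattus norvegicus as the target, read by paw edema, with a stated time of 1 h, at a dose of 0.28 mmol/kg by the oral route (on this read-out higher numbers stand for more inhibition at the one dose given (going by the name of the read-out) and lower numbers for less inhibition), where compound 1 gives 63%. For the measured compounds named here, its single measured neighbour is compound 2 `CCn1c(SC/C(=N/O)c2ccccc2)nnc1-c1ccc(OC)c(OC)c1`, which in this assay gives 61%. Going by the values given here, the one step joining them, a number 2 percentage points lower from compound 1 to compound 2 (within the scatter), removes a methoxy group from an aromatic carbon; the two numbers lie within the scatter of each other, so compound 1 is not set apart from compound 2 on the numbers seen so far.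

Compound 3 `COc1cc(-c2nnc(SC/C(=N/O)c3ccccc3)n2-c2ccccc2)cc(OC)c1OC` is not yet measured. It differs from compound 1 in one place: phenyl in place of ethyl on an aromatic nitrogen. Among the compounds with values here, none of the measured steps touches the group on the ring nitrogen; the only step on record concerns a methoxy group on an aromatic carbon, so nothing measured bears directly on this change. Within the data shown here, with no step to lean on, the expectation is that compound 3 stays near compound 1, and a shift beyond the scatter in either direction cannot be ruled out. The expected step is a number 3 percentage points lower from compound 1 to compound 3 (within the scatter). Compound 3 is therefore estimated to give 60% in this assay, within a range from 40% to 76%.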

Compound 3, a percentage reported as inhibition, in the whole organism at one dose (the size of the read-out at that dose, not a potency): 61%
Compound 3: middle estimate off by 1 percentage points, on the low side; measured number inside the range.
By their numbers in this assay, from the lowest: compounds 2, 3 and 1 (each within the scatter of the next).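

Placed on the aromatic nitrogen of the five-membered ring, phenyl in place of ethyl gives, in this assay, a number 2 percentage points lower from compound 1 to compound 3 (within the scatter). For the compounds shown here, this is the first measured step at this position, and it shows that an ethyl of 2 heavy atoms and a phenyl of 6 heavy atoms, which brings a six-membered aromatic ring, are not told apart by this read-out at the one dose given, even though this nitrogen lies next to two ring atoms that each bear a large group. No measurement of any property of these compounds is available to explain this result.

The compounds shown leave open whether other groups on this nitrogen, such as a longer chain like butyl, a benzyl, or a phenyl carrying an amine or a carboxylic acid, would also stay within the scatter of compound 1 or would move the number beyond it. Since each compound is read at a single dose and a single time, they also leave open whether compound 1 and compound 3 would still match at other doses or times.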